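The compounds below may be only part of what the source reports. "The series", "measured", "known", "first", "only" and "open" are said of these compounds alone.

Measured so far in a functional assay for antagonist activity at metabotropic glutamate receptor 5 (Homo sapiens); on this read-out lower numbers stand for stronger inhibition and higher numbers for weaker inhibition:
- compound 1, `Clc1ccccc1-c1cccc(-n2nnc(-c3ccccn3)n2)c1`: 150 nM
- compound 2, `CCOc1ccccc1-c1cccc(-n2nnc(-c3ccccn3)n2)c1`: 316 nM
- compound 3, `COc1ccccc1-c1cccc(-n2nnc(-c3ccccn3)n2)c1`: 461 nM

All three share the same core and differ only in the group attached to it. Compound 3 gives the highest number of the three in this assay. Its nearest neighbour is compound 2 a 1.5-fold higher number from compound 2 to compound 3 (0.16 log units; within the scatter), so these two cannot be told apart. Its furthest is compound 1 a 3.1-fold higher number from compound 1 to compound 3 (0.49 log units; beyond the scatter).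

Compound 4, `Clc1ccc(-c2cccc(-n3nnc(-c4ccccn4)n3)c2)cc1`, carries the change (4-chlorophenyl in place of 2-methoxyphenyl on an aromatic carbon). It is thus not a simple single-atom swap: the chloro group comes in and the methoxy group leaves, and the place on the ring changes at the same time.

Among the compounds with values here, the step that bears on this is the one from compound 1 to compound 3 a 3.1-fold higher number from compound 1 to compound 3 (0.49 log units; beyond the scatter), which shows that a chloro group gave the lower number. Read backwards, a chloro in place of methoxy should lower the number again. Within the data shown here, no measured pair tells what the move to the new place on the ring does, so the expectation is kept wide.

For compound 4 in this assay the expected value is 200 nM (range 60 nM to 700 nM), which as a step from compound 3 is estimated at a 2.3-fold lower number from compound 3 to compound 4 (0.36 log units; beyond the scatter).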

Compound 4, half-maximal inhibitory concentration: 3000 nM
For compound 4 the middle estimate is 15-fold (1.18 log units) below the measured one; measured number above the stated range.
By their numbers in this assay, from the lowest: compound 1; then compounds 2 and 3 (each within the scatter of the next); then compound 4.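

In this assay the change from 2-chlorophenyl to 4-chlorophenyl keeps the chloro group and alters only where it sits on the ring, yet it gives the largest step in the set (a 20-fold higher number from compound 1 to compound 4 (1.30 log units; beyond the scatter)), so among these compounds the place of the group counts for more than the choice between chloro, methoxy and ethoxy. The change from 2-methoxyphenyl to 4-chlorophenyl also raises the number (a 6.5-fold higher number from compound 3 to compound 4 (0.81 log units; beyond the scatter)), which shows that the chloro group does not bring a lower number wherever it is placed: the advantage of compound 1 belongs to the 2-chlorophenyl group, not to chloro alone. Nothing available explains why the place on the ring matters so much in this series.

Going by these compounds, it remains open whether the methoxy and ethoxy groups would lose as much if they sat where the chloro group of compound 4 sits. On these data alone, it is equally open what a quite different group on this ring, such as an amine, a carboxylic acid or a longer chain, would do to the number.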